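A few compounds are considered here, and "the series" means these few. Any claim that something is new, unique, unknown or untested is made for them only; others in the source may bear on it.

Three compounds have been measured in an assay on JEG-3 cells for inhibition of Aromatase (Homo sapiens), with a stated time of 1 h; a higher number here means a weaker inhibitor, a lower number a stronger inhibitor:

Compound 1, `COc1ccc2oc(C(c3ccc(Cl)cc3)n3cncn3)cc2c1`, gives 2.01 nM.
Compound 2, `COc1ccc(C(c2cc3cc(Cl)ccc3o2)n2cncn2)cc1`, gives > 1000 nM.
Compound 3, `Oc1ccc2oc(C(c3ccc(Cl)cc3)n3cncn3)cc2c1`, gives 5.67 nM.

Compound 1 and compound 2 are built from the same atoms joined differently; the difference between the two cores is not broken down here. The value of compound 2 in this assay is a limit of the assay, not a number. Compound 3 arises from compound 1 through (hydrogen in place of methyl on an oxygen on an aromatic ring), and the measured result is a 2.8-fold higher number from compound 1 to compound 3 (0.45 log units; beyond the scatter) in this assay.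

Compound 4, `Oc1ccc(C(c2cc3cc(Cl)ccc3o2)n2cncn2)cc1`, has not yet been measured in this assay. It arises from compound 2 through the same change, (hydrogen in place of methyl on an oxygen on an aromatic ring). Because compound 2 sits at the limit of > 1000 nM in this assay, at which 1 of the 3 values shown sits, the starting point for this second step is known only as a limit. In this assay the expected step is a step that the limit leaves unreadable from compound 2 to compound 4. This expectation rests on compound 1 and compound 3, where the same change gave a 2.8-fold higher number from compound 1 to compound 3 (0.45 log units; beyond the scatter). Compound 4 is therefore estimated to give about 3000 nM in this assay, expected to lie between 1000 nM and 15000 nM, and most likely only a limit will again be reported.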

Compound 4, half-maximal inhibitory concentration: 30.3 nM
Compound 4: the middle estimate sits 99-fold (2.00 log units) above what was measured, outside the stated range (below it).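

In this assay, replacing methoxy with hydroxy on the core of compound 2 gives an at least 33-fold lower number from compound 2 to compound 4 (1.51 log units; beyond the scatter). Compound 2 gives > 1000 nM, which is a limit of the assay and not a number. The effect of this change cannot be carried from one core to the other in this series, since it runs in opposite directions on the two cores, although these two pairs do not show why the cores differ or how the change would behave on any further core: the same change on two cores in this assay, a 2.8-fold higher number (0.45 log units; beyond the scatter) from compound 1 to compound 3 and an at least 33-fold lower number (1.51 log units; beyond the scatter) from compound 2 to compound 4, at least 93-fold (1.96 log units) apart, beyond the scatter of two such steps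

The compounds shown leave open whether this split between the two cores is particular to the hydroxy group or would also appear with another group on the same aromatic ring, such as an amine or a carboxylic acid. They also leave open whether a longer chain on the oxygen, such as ethoxy, would follow the methoxy or the hydroxy compounds on either core.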